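The source may hold more compounds than are shown below. What is called first, only, known or untested is meant among the compounds shown, and "the series" means these compounds.

Compound 1 `O=C1C=CC2(C=C1)OCC(=O)N2S(=O)(=O)c1ccccc1`: > 10000 nM
Compound 2 `Cc1ccc(S(=O)(=O)N2C(=O)C(C)OC23C=CC(=O)C=C3)cc1`: > 10000 nM
Compound 3 `N#Cc1cccc(S(=O)(=O)N2C(=O)COC23C=CC(=O)C=C3)c1`: 180 nM

In a functional assay on HeLa cells (Homo sapiens) for inhibition, read by sulforhodamine B assay, with a stated time of 74 h (a higher number here means a weaker inhibitor, a lower number a stronger inhibitor), compound 1 gives > 10000 nM, which is a limit and not a number. Compound 1 thus sits at the limit of > 10000 nM in this assay, at which 2 of the 3 values shown sit. Compound 2 gives > 10000 nM, also a limit. Compound 3 reads 180 nM, a true number. Compound 4 `O=C1C=CC2(C=C1)OCC(=O)N2S(=O)(=O)c1ccc(N2CCCC2=O)cc1` is not yet measured. It differs from compound 1 by 2-oxopyrrolidin-1-yl in place of hydrogen on an aromatic carbon. Within the data shown here, the only measured step that bears on this is an at least 55-fold lower number from compound 1 to compound 3 (1.74 log units; beyond the scatter), made by a different group, so it is a loose guide. A lower number is expected in this assay, but a smaller drop, with an at least 3.3-fold lower number from compound 1 to compound 4 (0.52 log units; beyond the scatter) as the estimated step. For compound 4 the estimate is 3000 nM, with an expected range from 400 nM to 15000 nM.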

Compound 4, half-maximal inhibitory concentration: 880 nM
Compound 4: the middle estimate sits 3.4-fold (0.53 log units) above what was measured, and the stated range covers the measured number.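

In this assay, among these compounds, 2-oxopyrrolidin-1-yl in place of hydrogen gives an at least 11-fold lower number from compound 1 to compound 4 (1.05 log units; beyond the scatter), so the nitrile of compound 3 is not the only group on the aromatic ring that goes with a measured value. This also shows that a group with its own five-membered ring is accepted at this place, para to a large group. The true size of the step stays unknown, because the value of compound 1 is a limit: the limit of > 10000 nM in this assay, at which 2 of the 4 values shown sit.

As far as these compounds go, whether an amine or an open-chain amide at this place would read the same remains open. So does how a nitrile would read here.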